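A second fluoro group on compound 2

The source may report more compounds than this note shows. Statements on the series, on what has been measured and on what is new or still open speak of the compounds shown alone.

In an ADME assay on HepG2 2.2.15 cells (Homo sapiens) for cytotoxicity, read by MTT assay (on this read-out lower numbers stand for higher toxicity in this test and higher numbers for lower toxicity in this test), compound 1 (`COc1cccc(/C=C/C(=O)Oc2ccc(C(C)=O)cc2)c1`) gives > 2780000 nM, which is a limit. Compound 2 (`CC(=O)c1ccc(OC(=O)/C=C/c2cccc(F)c2)cc1`) gives > 3100000 nM, also a limit, so its true position is not known. Compound 3 (`CC(=O)c1ccc(OC(=O)/C=C/c2ccc(F)c(F)c2)cc1`) carries fluoro in place of hydrogen on an aromatic carbon, ortho to a fluoro group and para to a large group (fluoro in place of hydrogen on an aromatic carbon). For the measured compounds named here, the only measured step that bears on this change is a step that the two limits leave unreadable from compound 1 to compound 2, and it has no readable size. No step beyond the scatter is therefore expected, and the expected step is an at least 1.0-fold lower number from compound 2 to compound 3 (0.01 log units; that floor lies within the scatter). The estimate for compound 3 is 3000000 nM, with an expected range from 1500000 nM to 6000000 nM.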

Compound 3, half-maximal cytotoxic concentration: > 2590000 nM
Compound 3: only a limit was reported; the forecaster's own chance of this, stated with the estimate: 85%; the middle value lies beyond the limit too.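

Compound 2 and compound 3 are both reported only as limits in this assay, so no step can be read between them. The compounds shown leave open at what concentration any of them reaches the half-maximal cytotoxic level.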